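The compounds below may be only part of what the source reports. "The series", "measured", "known", "first", "only" and "open" are said of these compounds alone.

Of the compounds shown here, three built on one shared core have been measured in an assay on isolated protein for inhibition of RAC-alpha serine/threonine-protein kinase (Homo sapiens), tested at 30 uM; on this read-out lower numbers stand for less inhibition and higher numbers for more inhibition at the one concentration tested (going by the name of the read-out). Compound 1, `Fc1ccc(Cn2cnc3c(Cl)ncnc32)cc1`, gives 0%. Compound 2, `Nc1ncnc2c1ncn2Cc1ccc(F)cc1`, gives 0%. The step of no change at the digits printed from compound 1 to compound 2 (within the scatter) shows that swapping one group for another at that place on the core left the read-out where it was. Compound 3, `Fc1ccc(Sc2ncnc3c2ncn3Cc2ccccc2)cc1`, gives 1%, which sits at the same level as compound 1 and compound 2: the gaps to both lie within the scatter, so none of the three can be set apart from the others, and all sit near the bottom of the scale, showing hardly any inhibition.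

Compound 4, `Fc1ccc(Cn2cnc3c(Sc4ccc(F)cc4)ncnc32)cc1`, differs from compound 3 in one place: fluoro in place of hydrogen on an aromatic carbon. Within the data shown here, no measured pair bears directly on this change; the one known step, from compound 1 to compound 2, concerns a different group, and it did not move the read-out. With all three measured compounds near zero and nothing in the data pointing to a rise, the step of a number 1 percentage points higher from compound 3 to compound 4 (within the scatter) is expected to lie within the scatter. Compound 4 is therefore estimated at 2% in this assay, with a range from -5% to 12%.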

Compound 4, a percentage reported as inhibition, at one concentration (the size of the read-out at that concentration, not a potency): 0%
Compound 4: middle estimate off by 2 percentage points, on the high side; measured number inside the range.
By their numbers in this assay, from the lowest: compounds 1, 2, 4 and 3 (each within the scatter of the next).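

In this assay, fluoro in place of hydrogen, which turns the benzyl into 4-fluorobenzyl, gives a number 1 percentage points lower from compound 3 to compound 4 (within the scatter) and so adds a second place on the shared core where a swap leaves the read-out where it was. The earlier compounds had shown this only for amino against chloro, while the new group at that place gives no change at the digits printed from compound 2 to compound 4 (within the scatter) when (4-fluorophenyl)sulfanyl stands in place of amino and no change at the digits printed from compound 1 to compound 4 (within the scatter) when it stands in place of chloro, so a much bigger group there does not lift the number either. No separate measurement is at hand that could explain this flat picture.

All four compounds sit near the bottom of the scale, so these steps cannot tell which parts of the molecule matter for inhibition, or whether either place could matter at all. On these data alone, it remains open whether a carboxylic acid or a methoxy on the benzyl ring, or a longer chain such as a piperidinylethyl amine in place of the (4-fluorophenyl)sulfanyl, would move the read-out off the floor.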